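Cyclopentanediol series: chain amides, cytotoxicity on S2 cells

The compounds below may be only part of what the source reports. "The series", "measured", "known", "first", "only" and "open" are said of these compounds alone.

Measured so far, in an ADME assay on S2 cells (Drosophila melanogaster) for cytotoxicity, read by MTT assay; on this read-out higher numbers stand for an effect only at larger amounts of compound and lower numbers for an effect already at smaller amounts:
- compound 1 `CCC[C@H]1C[C@@H](O)[C@@H](O)C1`: a limit only, > 350000 nM
- compound 2 `CNC(=O)CC[C@H]1C[C@@H](O)[C@@H](O)C1`: a limit only, > 250000 nM
- compound 3 `CNC(=O)C[C@H]1C[C@@H](O)[C@@H](O)C1`: a limit only, > 250000 nM

Compound 1 stands at the limit (the limit of > 350000 nM in this assay, at which 1 of the 3 values shown sits), so no number is known for it. The other two values shown are likewise limits, at the limit of > 250000 nM in this assay, at which 2 of the 3 values shown sit. The step that the two limits leave unreadable from compound 1 to compound 2 and the step that the two limits leave unreadable from compound 1 to compound 3 are thus both unreadable; they tell only that adding a methylcarbamoyl to the chain left no effect within the tested range.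

Compound 4 `CNC(=O)CCC[C@H]1C[C@@H](O)[C@@H](O)C1` carries methylcarbamoyl in place of hydrogen on a saturated chain carbon, three bonds along the chain from a saturated ring carbon. The two measured steps bear on it, since each also introduces a methylcarbamoyl on the chain, and neither produced a readable number. No step in either direction beyond the scatter is therefore expected in this assay ; the step of an at least 1.1-fold lower number from compound 1 to compound 4 (0.06 log units; that floor lies within the scatter) is expected to be nil. Compound 4 is estimated at 300000 nM, and most probably this assay will again report only a limit. For compound 4 the range is estimated from 100000 nM to 900000 nM.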

Compound 4, half-maximal effective concentration: > 250000 nM
Compound 4 ended at the assay's limit; the forecaster's own chance of this, stated with the estimate: 85%; the middle value does not contradict the limit.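

In this assay compound 4 gives only a limit, > 250000 nM. For the compounds shown here, compound 1 also stands at a limit, so no step from it to compound 4 can be read. The compounds shown leave open whether any of these chain amides differs from compound 1 in this assay.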